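Swapping Methoxy for Methyl on a Shared Core

This account rests on a few compounds, and the source may have more. Where it says the series, first, only, none or still open, it means among the compounds named here.

Two related compounds sit close together in an ADME assay on cells (Hepatocyte, Homo sapiens) for metabolic stability; a lower number here means that the compound disappears faster, a higher number that the compound lasts longer. Compound 1 `CCc1nc2ccc(Cl)cn2c1C(=O)NCCOc1ccc(Br)cc1` gives 0.587 h and compound 2 `COc1ccc2nc(C)c(C(=O)NCCOc3ccc(Br)cc3)n2c1` gives 0.903 h, a gap within the usual scatter. Compound 3 `Cc1ccc2nc(C)c(C(=O)NCCOc3ccc(Br)cc3)n2c1` keeps the rest of compound 2 but has methyl in place of methoxy on an aromatic carbon. For the measured compounds named here, no measured pair shows this change on its own, so there is no direct guide to its size, and no step beyond the scatter is expected. The expected move a 1.1-fold lower number from compound 2 to compound 3 (0.05 log units; within the scatter) is small. Compound 3 is estimated at 0.8 h, with a range from 0.4 h to 1.6 h.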

Compound 3, half-life: 0.108 h
Compound 3: the middle estimate sits 7.4-fold (0.87 log units) above what was measured; measured number below the stated range.
By their numbers in this assay, from the lowest: compound 3; then compounds 1 and 2 (each within the scatter of the next).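

This position on the shared core matters: in this assay, methyl in place of methoxy on an aromatic carbon gives an 8.4-fold lower number from compound 2 to compound 3 (0.92 log units; beyond the scatter), a step beyond the scatter. Compound 1 and compound 2 differ in more than one place, so they could not show the effect of this single change. Nothing measured here explains the step.

Still open, from the compounds shown here alone, is whether methoxy is unusual at this position or methyl is. Comparing ethoxy or a single fluorine atom at the same place on the same core would help separate the two.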